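A few compounds are considered here, and "the series" means these few. Any claim that something is new, unique, unknown or untested is made for them only; others in the source may bear on it.

Compound 1, `Cc1ccc(-n2nncc2CN2C(=O)C3(C(C#N)=C(N)Oc4c(N)cc5nc6ccccc6nc5c43)c3ccccc32)cc1C`: in a functional assay on A549 cells (Homo sapiens) for antiproliferative activity, read by MTT assay, with a stated time of 48 h (a lower number here means a stronger inhibitor, a higher number a weaker inhibitor), compound 1 gives > 50000 nM, a limit of the assay rather than a number.
Compound 2, `N#CC1=C(N)Oc2c(N)cc3nc4ccccc4nc3c2C12C(=O)N(Cc1cnnn1-c1ccc(Cl)cc1Cl)c1ccccc12`: compound 2 gives > 50000 nM, again a limit and not a number.
Compound 3, `Cc1ccc(-n2nncc2CN2C(=O)C3(C(C#N)=C(N)Oc4c(N)cc5nc6ccccc6nc5c43)c3ccccc32)cc1Cl`: compound 3 gives 11800 nM.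

Going by the values given here, compound 3 therefore holds the only number in this set, the other two values being limits (the limit of > 50000 nM in this assay, at which 2 of the 3 values shown sit). The step from compound 1 to compound 3 is an at least 4.2-fold lower number from compound 1 to compound 3 (0.62 log units; beyond the scatter), and the step from compound 2 to compound 3 is an at least 4.2-fold lower number from compound 2 to compound 3 (0.62 log units; beyond the scatter), while the step from compound 1 to compound 2 is a step that the two limits leave unreadable from compound 1 to compound 2.

Compound 4, `COc1cc(-n2nncc2CN2C(=O)C3(C(C#N)=C(N)Oc4c(N)cc5nc6ccccc6nc5c43)c3ccccc32)c(OC)cc1Cl`, carries the change (4-chloro-2,5-dimethoxyphenyl in place of 3-chloro-4-methylphenyl on an aromatic nitrogen). Both measured steps into compound 3 show that the aryl group on the triazole nitrogen moves the number by a lot, and in both cases the other aryl group gives only a limit. The entering 4-chloro-2,5-dimethoxyphenyl differs from the 3-chloro-4-methylphenyl more than either of those two groups does, so the expected step from compound 3 to compound 4 in this assay is a 2.1-fold higher number from compound 3 to compound 4 (0.33 log units; beyond the scatter), towards a higher number. For compound 4 the estimate is 25000 nM, with a range from 8000 nM to 80000 nM.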

Compound 4, half-maximal inhibitory concentration: > 50000 nM
Compound 4 was reported as a limit (the forecaster's own chance of this, stated with the estimate: 45%); middle value at least 2.0-fold (0.30 log units) away from the limit.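

In this assay, going by these compounds, replacing the 3-chloro-4-methylphenyl on the aromatic nitrogen with 4-chloro-2,5-dimethoxyphenyl gives an at least 4.2-fold higher number from compound 3 to compound 4 (0.62 log units; beyond the scatter), and because compound 4 is reported only as a limit, the true size of this step stays open beyond what is printed. Compound 3 now stands alone among the three aryl groups tested against it, and the chlorine on the aryl ring is not enough by itself to give a number, since compound 2 and compound 4 both carry chlorine and both stop at the same limit: the limit of > 50000 nM in this assay, at which 3 of the 4 values shown sit.
The steps among compound 1, compound 2 and compound 4 have limits at both ends and cannot be read.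

Compound 4 differs from compound 3 in the chlorine's place, the loss of the methyl and the gain of two methoxy groups all at once, so the compounds shown do not tell which of these carries the step. On these data alone, what a single methoxy, a lone chloro, a lone methyl, or an amine or carboxylic acid on this phenyl ring would give also remains open.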